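The compounds below may be only part of what the source reports. "The series", "measured", "known", "first", "only" and "open" are said of these compounds alone.

Measured so far in a functional assay on HT-29 cells (Homo sapiens) for inhibition, read by MTT assay, with a stated time of 72 h; on this read-out higher numbers stand for weaker inhibition of growth and lower numbers for stronger inhibition of growth:
- compound 1 `O=S(=O)(NCCNCc1cccc2ccccc12)c1cc(C(F)(F)F)cc(C(F)(F)F)c1` gives 16000 nM
- compound 3 `CC(C)(C)c1ccc(CNCCNS(=O)(=O)c2cc(C(F)(F)F)cc(C(F)(F)F)c2)cc1` gives 14000 nM
- compound 2 `CN(CCCNS(=O)(=O)c1cc(C(F)(F)F)cc(C(F)(F)F)c1)Cc1ccccc1` gives only a limit, > 50000 nM

Among the measured compounds shown here, compound 2 is the one compound of the three without a number: its result in this assay is a limit, (the limit of > 50000 nM in this assay, at which 1 of the 3 values shown sits). For the measured compounds named here, compounds 1 and 3 both carry a secondary amine and both return numbers; the one measured step, a 1.1-fold lower number from compound 1 to compound 3 (0.06 log units; within the scatter), shows that swapping the aromatic group on that amine changes little.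

Compound 4 `O=S(=O)(NCCCNCc1ccc(Cl)cc1)c1cc(C(F)(F)F)cc(C(F)(F)F)c1` is reached from compound 2 by (4-chlorobenzyl)amino in place of benzyl(methyl)amino on a saturated chain carbon, three bonds along the chain from a sulfonamide nitrogen. This change restores the secondary amine seen in compounds 1 and 3 and replaces the aromatic group, the kind of swap that gave a 1.1-fold lower number from compound 1 to compound 3 (0.06 log units; within the scatter). Going by the values given here, no measured step separates a methylated from an unmethylated amine, so the size of the effect has to be inferred from compound 2 sitting at the limit while compounds 1 and 3 do not.

Compound 4 is therefore expected to give a number rather than a limit, near the range of compounds 1 and 3, estimated as 20000 nM (range 8000 nM to 50000 nM), which would mean an expected step of an at least 2.5-fold lower number from compound 2 to compound 4 (0.39 log units; beyond the scatter).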

Compound 4, concentration for 50% growth inhibition: 2800 nM
Compound 4: the middle estimate sits 7.1-fold (0.85 log units) above what was measured; the measured number lies below the stated range.
By their numbers in this assay, from the lowest: compound 4; then compounds 3 and 1 (each within the scatter of the next). At a limit, above all of these: compound 2.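

In this assay, among the compounds shown here, the change on a saturated chain carbon, three bonds along the chain from a sulfonamide nitrogen, gives an at least 17-fold lower number from compound 2 to compound 4 (1.25 log units; beyond the scatter), whereas the one earlier step, a 1.1-fold lower number from compound 1 to compound 3 (0.06 log units; within the scatter), stayed within the scatter. Unlike that swap of aromatic groups on a secondary amine, this change moves the read-out by a large amount, and the printed size is only a minimum. Compound 2 stands at a limit, not at a number: the limit of > 50000 nM in this assay, at which 1 of the 4 values shown sits.

The change from benzyl(methyl)amino to (4-chlorobenzyl)amino alters both the methyl on the amine and the chlorine on the aromatic ring, and the compounds shown do not divide the step between the two. Also open, going by these compounds, is how a 4-fluorobenzyl or 4-methoxybenzyl group on the amine, or a longer chain to the sulfonamide nitrogen, would read.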